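A few compounds are considered here, and "the series" means these few. Any claim that something is new, unique, unknown or untested is made for them only; others in the source may bear on it.

Measured so far:
- compound 1 `O=C(Nc1ccccc1OC(F)(F)F)Nc1n[nH]c2ccccc12`: 36200 nM
- compound 2 `O=C(Nc1ccc(Cc2ccccc2)cc1)Nc1nn(C(=O)Nc2ccc(Cc3ccccc3)cc2)c2ccccc12`: > 100000 nM
- compound 3 `Nc1nn(C(=O)Nc2ccc(Cc3ccccc3)cc2)c2ccccc12`: 1080 nM

Of the compounds shown here, three carrying the shared core have been tested in a functional assay on HCT-15 cells (Homo sapiens) for inhibition, read by sulforhodamine B assay, with a stated time of 48 h; on this read-out lower numbers stand for stronger inhibition of growth and higher numbers for weaker inhibition of growth. Compound 1 gives 36200 nM. For compound 2 the assay reports only a limit, > 100000 nM, and no number. Compound 3 gives 1080 nM, the lowest of the two actual numbers; the nearest number, that of compound 1, lies higher by a gap well beyond the usual scatter, so compound 3 stands apart from it on this read-out.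

Compound 4 `CCCCOc1ccc(NC(=O)n2nc(N)c3ccccc32)cc1` has not yet been measured in this assay. It differs from compound 3 in one place: butoxy in place of benzyl on an aromatic carbon. Among the measured compounds shown here, no pair among the measured compounds carries a comparable change, so no measured step can be borrowed for it, and the guess rests on the size and kind of the exchanged groups alone. A modest step toward a higher number, of a size that could still sit within the scatter, is expected a 1.9-fold higher number from compound 3 to compound 4 (0.27 log units; within the scatter). On that basis compound 4 is estimated to give about 2000 nM in this assay, with a likely range from 500 nM to 8000 nM.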

Compound 4, concentration for 50% growth inhibition: 15500 nM
Compound 4: the middle estimate sits 7.8-fold (0.89 log units) below what was measured; the whole stated range lies below it.
By their numbers in this assay, from the lowest: compound 3; then compound 4; then compound 1. At a limit, above all of these: compound 2.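

In this assay, exchanging benzyl for butoxy on the aromatic carbon, para to a large group, gives a 14-fold higher number from compound 3 to compound 4 (1.16 log units; beyond the scatter), a large step that shows that the growth inhibition seen with compound 3 does not survive every change at this position. The exchange removes a six-membered aromatic ring of carbon only and brings in an open chain with an oxygen and a hydrogen-bond acceptor, and these differences travel together in this one pair, so the step cannot be assigned to any one of them. Nothing among the data shown accounts for the size of this step.

On these data alone, it remains open whether the loss of the ring or the arrival of the oxygen weighs more: a phenoxy group would keep a ring alongside the oxygen, while a pentyl chain would have no ring and no oxygen. As far as these compounds go, it is also open how a shorter ethoxy chain, an amine or a carboxylic acid at this position would read out, and whether any group here could give a lower number than benzyl does.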